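Aniline variation on the shared core: outlook for compound 4

This account rests on a few compounds, and the source may have more. Where it says the series, first, only, none or still open, it means among the compounds named here.

Compound 1 `CNC(=O)c1ccccc1Oc1nc(Nc2ccccc2F)ncc1Br` sits at the limit of a functional assay on HL-60 cells (Homo sapiens) for antiproliferative activity, read by MTT assay, with a stated time of 24 h; a higher number here means a weaker inhibitor, a lower number a stronger inhibitor: compound 1 returns > 50000 nM, which is a limit and not a number. Compound 2 `CNC(=O)c1ccccc1Oc1nc(Nc2ccc(Cl)cc2F)ncc1Br` gives > 50000 nM in this assay, again a limit. Compound 3 `CNC(=O)c1ccccc1Oc1nc(Nc2cccc(C(F)(F)F)c2)ncc1Br` gives 44000 nM in this assay, a number. The step that the two limits leave unreadable from compound 1 to compound 2 stays unreadable, as the limit of > 50000 nM in this assay, at which 2 of the 3 values shown sit, leaves it. Compound 4 `CNC(=O)c1ccccc1Oc1nc(Nc2cccc(OC)c2)ncc1Br` carries 3-methoxyphenyl in place of 2-fluorophenyl on a nitrogen on an aromatic ring. Going by the values given here, no measured step speaks to a 3-methoxyphenyl; the only number, that of compound 3, lies close to the limit, and the other two values are limits. No step beyond the scatter is therefore expected in this assay. Compound 4 is expected at 60000 nM, with a range from 20000 nM to 150000 nM, most likely reported as a limit. The step that the limit leaves unreadable from compound 1 to compound 4 is expected to remain within the scatter.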

Compound 4, half-maximal inhibitory concentration: 16200 nM
Compound 4: the middle estimate sits 3.7-fold (0.57 log units) above what was measured; measured number below the stated range.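

In this assay, the substituent on the aniline ring now moves a real number: methoxy in place of trifluoromethyl on an aromatic carbon gives a 2.7-fold lower number from compound 3 to compound 4 (0.43 log units; beyond the scatter). 3-Methoxyphenyl on the same nitrogen also separates from the earlier halogenated anilines, with an at least 3.0-fold lower number from compound 1 to compound 4 (0.48 log units; beyond the scatter) and an at least 3.0-fold lower number from compound 2 to compound 4 (0.48 log units; beyond the scatter). Those two steps are bounds only, each set by a limit: the limit of > 50000 nM in this assay, at which 2 of the 4 values shown sit.

As far as these compounds go, whether an amine or a longer alkoxy chain in place of methoxy would lower the number further stays open. So does whether a hydroxyl group would keep the step.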